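A methyl group added to a compound at the assay limit

The compounds below may be only part of what the source reports. "The series", "measured", "known", "first", "only" and "open" are said of these compounds alone.

Compound 1 `COc1cc(-c2nnc3c(OC)cc(-c4ccc5[nH]ccc5c4)cn23)cc(OC)c1OC`: 108 nM
Compound 2 `COc1cc(-c2nnc3c(OC)cc(-c4ccc5[nH]cc(C=O)c5c4)cn23)cc(OC)c1OC`: > 10000 nM

In a functional assay on HCT-116 cells (Homo sapiens) for antiproliferative activity, read by MTT assay, with a stated time of 48 h (on this read-out higher numbers stand for weaker inhibition and lower numbers for stronger inhibition), compound 1 gives 108 nM. Compound 2 reads > 10000 nM, which is a limit of the assay and not a number. Compound 2 therefore stands at the limit of > 10000 nM in this assay, at which 1 of the 2 values shown sits. Going by the values given here, the only measured step is an at least 92-fold higher number from compound 1 to compound 2 (1.96 log units; beyond the scatter), with formyl in place of hydrogen on an aromatic carbon.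

Compound 3 `COc1cc(-c2nnc3c(OC)cc(-c4ccc5c(c4)c(C=O)cn5C)cn23)cc(OC)c1OC` keeps that formyl group and differs from compound 2 by methyl in place of hydrogen on an aromatic nitrogen. Among the compounds with values here, no measured step touches that nitrogen. The step of an at least 92-fold higher number from compound 1 to compound 2 (1.96 log units; beyond the scatter) bears on it only indirectly, since compound 3 still carries the formyl group. No step beyond the scatter is therefore expected in this assay, and the reading may well again be a limit. The expected outcome is a number no higher from compound 2 to compound 3 (the limit leaves the size open). Compound 3 is estimated at 10000 nM, with an expected range of 3000 nM to 30000 nM.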

Compound 3, half-maximal inhibitory concentration: 1800 nM
Estimate against measurement, compound 3: 5.6-fold (0.74 log units) above; measured number below the stated range.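

In this assay, methyl in place of hydrogen on the aromatic nitrogen gives an at least 5.5-fold lower number from compound 2 to compound 3 (0.74 log units; beyond the scatter). Going by these compounds alone, this nitrogen, which no earlier step touched, is therefore a place where a small change moves the read-out even with the formyl group kept. As far as these compounds go, compound 3 also gives the formyl series a measured number rather than a limit, although the full size of the step stays open because one end of it is a limit: the limit of > 10000 nM in this assay, at which 1 of the 3 values shown sits.

From the compounds shown here alone, whether methyl on this nitrogen would move the read-out in the same direction in compound 1, which has no formyl group, remains open. So does how a longer chain such as ethyl on the nitrogen, or an amine or a carboxylic acid in place of the formyl group, would read.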